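The source may report more compounds than this note shows. Statements on the series, on what has been measured and on what is new or still open speak of the compounds shown alone.

Compound 2 `Cc1cc2cc(N/C=C\C(=O)c3nc(-c4ccc(F)cc4)n4ccccc34)ccc2[nH]1`: > 30000 nM
Compound 1 `O=C(/C=C\Nc1ccc(F)cc1)c1nc(-c2ccc(C(F)(F)F)cc2)n2ccccc12`: > 30000 nM
Compound 3 `COc1ccc(N/C=C\C(=O)c2nc(-c3ccccc3)n3ccccc23)cc1`: > 30000 nM

Each of these three results is a limit of a functional assay on A549 cells (Homo sapiens) for cytotoxicity, read by MTT assay, with a stated time of 48 h (on this read-out lower numbers stand for stronger inhibition and higher numbers for weaker inhibition), rather than a measured number. Compound 2 therefore stands only at a limit, and the two further values shown are limits as well, all sitting at the limit of > 30000 nM in this assay, at which 3 of the 3 values shown sit. Compound 4 `O=C(/C=C\Nc1ccc(Cl)cc1)c1nc(-c2ccc(F)cc2)n2ccccc12` has not yet been tested in this assay. It differs from compound 2 by 4-chlorophenyl in place of 2-methyl-1H-indol-5-yl on an amine nitrogen. No step between two measured compounds is available, and every result shown is a limit. For compound 4 in this assay, no movement beyond the scatter is expected. The expected step that the limit leaves unreadable from compound 2 to compound 4 is essentially none. Compound 4 is estimated at 40000 nM, within a range from 15000 nM to 120000 nM, and will most likely again be reported only as a limit.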

Compound 4, half-maximal inhibitory concentration: 5090 nM
Compound 4: middle estimate off by 7.9-fold (0.90 log units), on the high side; measured number below the stated range.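

In this assay, the group on the amine nitrogen clearly matters: 4-chlorophenyl in place of 2-methyl-1H-indol-5-yl gives an at least 5.8-fold lower number from compound 2 to compound 4 (0.77 log units; beyond the scatter). Compound 4 is the only one of the four compounds shown with a measured number rather than a limit. The full size of this step cannot be read, since compound 2 stands only at a limit, like two of the others: the limit of > 30000 nM in this assay, at which 3 of the 4 values shown sit.

As far as these compounds go, it remains open whether the chlorine or the change from the two-ring group to a single ring carries the step. From the compounds shown here alone, how a nitrile or a carboxylic acid in place of the chlorine would read also remains open.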